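Moving a fluorine on the aryl ring of compound 1

A few compounds are considered here, and "the series" means these few. Any claim that something is new, unique, unknown or untested is made for them only; others in the source may bear on it.

Measured compounds:
compound 1 `Cc1cc(C(=O)O)ccc1CN1CCC[C@H](O[C@H](CO)c2cc(Cl)cc(Cl)c2)[C@@H]1c1ccc(F)cc1` — 18000 nM
compound 2 `Cc1cc(C(=O)O)ccc1CN1CCC[C@@]2(C[C@@H](c3ccccc3)CO2)[C@@H]1c1ccccc1` — 43000 nM
compound 3 `Cc1cc(C(=O)O)ccc1CN1CCC[C@H](O[C@H](CO)c2cc(F)cc(F)c2)[C@@H]1c1ccccc1` — 1500 nM

Of the compounds shown here, three sharing one core have been tested in an assay on isolated protein for activation of cGMP-dependent protein kinase 1 (Homo sapiens), read by ADP-Glo, with stated times of 30 min and 2 h, in the presence of a further agent that is not named here; on this read-out lower numbers stand for an effect already at smaller amounts and higher numbers for an effect only at larger amounts of compound. Compound 1 gives 18000 nM, the second highest of the three numbers. Its nearest neighbour is compound 2, which in this assay gives 43000 nM, a higher number by a margin beyond the usual scatter. Farthest away lies compound 3, which gives 1500 nM, a much lower number, again well beyond the scatter. Compound 3 differs from compound 1 in two places at once, so no single change can be read from that gap.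

The next compound, compound 4 `Cc1cc(C(=O)O)ccc1CN1CCC[C@H](O[C@H](CO)c2cc(Cl)cc(Cl)c2)[C@@H]1c1cccc(F)c1`, has not yet been measured. It differs from compound 1 only in the arrangement of the same atoms: 3-fluorophenyl in place of 4-fluorophenyl on a saturated ring carbon

Among the compounds with values here, no pair of measured compounds differs in exactly one place, so there is no directly comparable step to lean on. Moving a single fluorine to another position on an otherwise unchanged aromatic ring is a small change, and the step from compound 1 to compound 4 is expected to stay within the scatter, estimated as a 1.1-fold lower number from compound 1 to compound 4 (0.05 log units; within the scatter). Compound 4 is therefore expected to give about 16000 nM in this assay, within a range of 6000 nM to 42000 nM.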

Compound 4, half-maximal effective concentration: 12000 nM
The estimate for compound 4 lay 1.3-fold (0.12 log units) above the measured number; the measured number falls inside the stated range.
By their numbers in this assay, from the lowest: compound 3; then compounds 4 and 1 (each within the scatter of the next); then compound 2.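

Within the data shown here, this is the first pair of measured compounds that differ in one place only, and that place is the saturated ring carbon next to the ring nitrogen. In this assay, putting 3-fluorophenyl in place of 4-fluorophenyl gives a 1.5-fold lower number from compound 1 to compound 4 (0.18 log units; within the scatter), so with the rest of the molecule unchanged, this assay does not separate the two fluorine placements. Nothing at hand gives a reason for this result.

These two fluorophenyl groups show only how far one fluorine can be moved on this ring without a change beyond the scatter, and they leave open whether a different group on the same ring, such as methoxy, an amine or a carboxylic acid, would have a larger effect on the number. The much wider gap between compound 1 and compound 3 also stays unexplained, since those two compounds differ in two places at once and a compound differing from compound 1 only in the chlorines on the 3,5-dichlorophenyl ring would be needed to begin to separate them.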